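Removing the benzyl ester chain from compound 3

The source may hold more compounds than are shown below. What is called first, only, known or untested is meant among the compounds shown, and "the series" means these compounds.

Of the compounds shown here, three sharing one core have been tested in a functional assay on the whole organism (Tail, strain ICR) with Mus musculus as the target, in the tail flick test, with a stated time of 30 min, at a dose of 25 umol/kg by the oral route; a lower number here means a weaker effect, a higher number a stronger effect of the compound at the dose given. Compound 1 `CSCC[C@H](NC(=O)CN(c1nc(Cl)nc2[nH]cnc12)C1CC1)C(=O)OCc1ccccc1` gives 22.2%. Compound 2 `O=C(CN(c1nc(Cl)nc2[nH]cnc12)C1CC1)N[C@@H](CC(=O)OCc1ccccc1)C(=O)OCc1ccccc1` gives 34.7%. Compound 3 `O=C(CN(c1nc(Cl)nc2[nH]cnc12)C1CC1)N[C@@H](CCC(=O)OCc1ccccc1)C(=O)OCc1ccccc1` gives 52.8%, the highest of the three numbers, with compound 2 nearest and compound 1 furthest behind.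

Compound 4 `C[C@@H](O)[C@H](NC(=O)CN(c1nc(Cl)nc2[nH]cnc12)C1CC1)C(=O)OCc1ccccc1` has not yet been measured in this assay. It differs from compound 3 in one place: 1-hydroxyethyl in place of 2-(benzyloxycarbonyl)ethyl on a saturated chain carbon bound to an amide-type nitrogen and a carbonyl carbon. The large benzyl ester chain is thus traded for a small, hydroxyl-bearing group.

Among the compounds with values here, no measured step makes exactly this change, but the three measured steps all point the same way: each time a benzyloxycarbonyl-bearing group entered or grew, the number rose, as in a number 30.6 percentage points higher from compound 1 to compound 3 (beyond the scatter), a number 18.1 percentage points higher from compound 2 to compound 3 (beyond the scatter) and a number 12.5 percentage points higher from compound 1 to compound 2 (beyond the scatter). Within the data shown here, compound 4 goes the opposite way, losing that group entirely, so a fall beyond the scatter is expected, roughly back to the level of compound 1 or somewhat lower, though the hydroxyl group has no measured counterpart here and adds uncertainty.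

Compound 4 is therefore expected to show a number 32.8 percentage points lower from compound 3 to compound 4 (beyond the scatter), giving an estimated 20% with a likely range from 5% to 38%.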

Compound 4, a percentage reported as activity, at one dose (the size of the read-out at that dose, not a potency): 21.9%
The estimate for compound 4 lay 1.9 percentage points below the measured number; measured number inside the range.
By their numbers in this assay, from the lowest: compounds 4 and 1 (each within the scatter of the next); then compound 2; then compound 3.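

At this position, on a saturated chain carbon bound to an amide-type nitrogen and a carbonyl carbon, 1-hydroxyethyl and 2-(methylsulfanyl)ethyl cannot be told apart in this assay, with a number 0.3 percentage points lower from compound 1 to compound 4 (within the scatter), even though only the first of these groups carries a hydrogen-bond donor. Swapping either chain that holds a benzyl ester for 1-hydroxyethyl lowers the number beyond the scatter, with a number 12.8 percentage points lower from compound 2 to compound 4 (beyond the scatter) and a number 30.9 percentage points lower from compound 3 to compound 4 (beyond the scatter), so across these four compounds the two with a second benzyl ester give the higher numbers. Nothing measured here explains this fall or the match between the two small chains.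

As far as these compounds go, what remains open is which part of the benzyl ester chain goes with the higher numbers: the benzene ring, the ester or simply the chain length, a question that a carboxylic acid in place of the ester or a plain 2-phenylethyl chain could help to answer. A simple ethyl group at this position would likewise show whether the hydroxyl of 1-hydroxyethyl makes any difference to the number.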